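The source may report more compounds than this note shows. Statements on the series, on what has been measured and on what is new or still open speak of the compounds shown alone.

Two sulfamate-bearing compounds sharing one core have been measured for inhibition of the target. Compound 1 `NS(=O)(=O)Oc1ccc2c(c1)CN(C(=O)c1ccc(N(Cc3ccccc3)Cc3ccco3)cc1)CC2` carries a benzyl and a furanylmethyl group on its aniline nitrogen, and in an assay on HEK293 cells for inhibition of Steryl-sulfatase (Homo sapiens), tested at 0.1 uM (on this read-out higher numbers stand for a stronger effect at the one concentration tested and lower numbers for a weaker effect), compound 1 gives 90.8%. Compound 2 `CC(C)CCN(CCC(C)C)c1ccc(C(=O)N2CCc3ccc(OS(N)(=O)=O)cc3C2)cc1` carries instead a diisopentylamino group, and in this assay compound 2 gives 47%. For the measured compounds named here, compound 2 thus stands lowest of the two numbers known here, and its nearest neighbour, compound 1, lies higher by a gap that is beyond the scatter of repeated measurements.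

Compound 3 `CCN(Cc1ccccn1)c1ccc(C(=O)N2CCc3ccc(OS(N)(=O)=O)cc3C2)cc1` has not yet been measured. It differs from compound 2 in one place: ethyl((pyridin-2-yl)methyl)amino in place of diisopentylamino on an aromatic carbon. The group that leaves has no ring, while the group that enters brings one six-membered aromatic ring with one hetero atom and a second hydrogen-bond acceptor. Going by the values given here, compound 1, whose nitrogen also bears ring-containing arylmethyl groups, gives 90.8%, which is the only guide available. On that guide compound 3 is expected to move upward from compound 2 in this assay by a number 23 percentage points higher from compound 2 to compound 3 (beyond the scatter), a step judged beyond the scatter. The estimated inhibition for compound 3 in this assay is 70%, with a range from 45% to 90%.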

Compound 3, a percentage reported as inhibition, at one concentration (the size of the read-out at that concentration, not a potency): 42.5%
Compound 3: the middle estimate sits 27.5 percentage points above what was measured; measured number outside the range, below it.
By their numbers in this assay, from the lowest: compounds 3 and 2 (each within the scatter of the next); then compound 1.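

At this position, on an aromatic carbon para to a large group, ethyl((pyridin-2-yl)methyl)amino in place of diisopentylamino gives in this assay a number 4.5 percentage points lower from compound 2 to compound 3 (within the scatter), so an open-chain group and one with a six-membered aromatic ring and a second hydrogen-bond acceptor read alike here. Compound 1, with a benzyl and a furanylmethyl group on the same nitrogen, gives 90.8%, and compound 3 shows that one ring-bearing arylmethyl group on that nitrogen does not by itself bring a number of that size. Nothing measured here on the compounds or their groups accounts for this result.

Going by these compounds, what stays open is whether the number of compound 1 depends on having two ring-bearing groups on the nitrogen, which a dibenzylamino or a bis((pyridin-2-yl)methyl)amino group would test. On these data alone, it is also open whether the ring nitrogen of the pyridine or the ethyl group counts for anything at this position, a question that a benzyl(ethyl)amino group or an N-benzyl-N-((pyridin-2-yl)methyl)amino group could address.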